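Azole swap on the shared core: outlook for compound 4

The source may report more compounds than this note shows. Statements on the series, on what has been measured and on what is new or still open speak of the compounds shown alone.

In a functional assay with Alpha-1B adrenergic receptor (Homo sapiens) as the target, read by calcium flux (on this read-out lower numbers stand for smaller maximal responses and higher numbers for larger maximal responses), compound 3 `c1ccc(-c2nc[nH]n2)c(NCC2=NCCN2)c1` gives 100%, the top of the three numbers, though compound 1 `Cn1ncnc1-c1ccccc1NCC1=NCCN1`, which gives 93%, sits within the scatter of it. Compound 2 `Cn1ccc(-c2ccccc2NCC2=NCCN2)n1` gives 33%. Compound 4 `Cn1ccnc1-c1ccccc1NCC1=NCCN1` is not yet measured and differs from compound 3 by 1-methyl-1H-imidazol-2-yl in place of 1H-1,2,4-triazol-3-yl on an aromatic carbon. Among the compounds with values here, two steps bear on this: a number 7 percentage points higher from compound 1 to compound 3 (within the scatter), where a methyl-bearing triazole gives way to an unsubstituted one, and a number 67 percentage points higher from compound 2 to compound 3 (beyond the scatter), where a methyl-bearing pyrazole does. The entering group carries a methyl like both, so the outcome could follow either; a moderate step down is expected, a number 25 percentage points lower from compound 3 to compound 4 (beyond the scatter), with wide uncertainty given compound 2 at 33%. Compound 4 is estimated at 75%, range 40% to 100%.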

Compound 4, largest response reached (reported as maximal response), in percent of the reference or control that the assay uses: 104%
Compound 4: middle estimate off by 29 percentage points, on the low side, outside the stated range (above it).
By their numbers in this assay, from the lowest: compound 2; then compounds 1, 3 and 4 (each within the scatter of the next, the first and the last beyond it).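

In this assay, the methyl-bearing 1-methyl-1H-imidazol-2-yl matches the unsubstituted triazole, a number 4 percentage points higher from compound 3 to compound 4 (within the scatter), so carrying a methyl does not by itself bring the low number of compound 2. The same group gives a number 71 percentage points higher from compound 2 to compound 4 (beyond the scatter) and a number 11 percentage points higher from compound 1 to compound 4 (beyond the scatter), which leaves compound 2 alone at the low end among these four azoles. No evidence at hand accounts for these steps. Open, on these data alone, is whether a carboxylic acid or an amide on this aromatic carbon keeps so large a maximal response, and whether an ethyl in place of the methyl does.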